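Chain-amine series: piperazine head in place of hydroxypiperidine

The compounds below may be only part of what the source reports. "The series", "measured", "known", "first", "only" and "open" are said of these compounds alone.

Of the compounds shown here, three sharing one core and an aminoalkoxy chain have been measured in an assay on isolated protein (Cavia porcellus) with Sigma non-opioid intracellular receptor 1 (Homo sapiens) as the target, read by radioligand binding; a higher number here means a weaker inhibitor, a lower number a stronger inhibitor. Compound 1 `CN(C)CCCCOc1ccc2oc(-c3ccccc3)cc(=O)c2c1` gives 400 nM. Compound 2 `O=c1cc(-c2ccccc2)oc2ccc(OCCCN3CCC(O)CC3)cc12` gives 123 nM and compound 3 `O=c1cc(-c2ccccc2)oc2ccc(OCCCCCCN3CCC(O)CC3)cc12` gives 121 nM. Compound 3 carries the lowest number of the three, but the step of a 1.0-fold lower number from compound 2 to compound 3 (0.01 log units; within the scatter) lies within the scatter, so compound 2 and compound 3 cannot be told apart; only compound 1 stands clearly higher, as shown by a 3.3-fold lower number from compound 1 to compound 2 (0.51 log units; beyond the scatter) and a 3.3-fold lower number from compound 1 to compound 3 (0.52 log units; beyond the scatter).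

Compound 4 `O=c1cc(-c2ccccc2)oc2ccc(OCCCCCCN3CCNC(CCO)C3)cc12` is not yet measured. It differs from compound 3 by 3-(2-hydroxyethyl)piperazin-1-yl in place of 4-hydroxypiperidin-1-yl on a saturated chain carbon, six bonds along the chain from an oxygen on an aromatic ring. For the measured compounds named here, no measured step exchanges one ring amine for another. The two steps that alter the amine head, a 3.3-fold lower number from compound 1 to compound 2 (0.51 log units; beyond the scatter) and a 3.3-fold lower number from compound 1 to compound 3 (0.52 log units; beyond the scatter), were modest, and the chain-length step a 1.0-fold lower number from compound 2 to compound 3 (0.01 log units; within the scatter) was flat. On that basis a small step is expected for compound 4 in this assay, a 1.5-fold higher number from compound 3 to compound 4 (0.17 log units; within the scatter), most likely within or only just beyond the scatter and in no firm direction. Compound 4 is therefore estimated at about 180 nM, with a range from 70 nM to 500 nM.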

Compound 4, half-maximal inhibitory concentration: 94 nM
The estimate for compound 4 lay 1.9-fold (0.28 log units) above the measured number, and the stated range covers the measured number.
By their numbers in this assay, from the lowest: compounds 4, 3 and 2 (each within the scatter of the next); then compound 1.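

In this assay, for the compounds shown here, the first exchange of one ring amine for another, 3-(2-hydroxyethyl)piperazin-1-yl in place of 4-hydroxypiperidin-1-yl on a saturated chain carbon six bonds along the chain from an oxygen on an aromatic ring, gives a 1.3-fold lower number from compound 3 to compound 4 (0.11 log units; within the scatter), so the number holds with the heavier head that adds a ring nitrogen and a hydrogen-bond donor. The head of compound 4 also stays clear of the dimethylamino compound, with a 4.3-fold lower number from compound 1 to compound 4 (0.63 log units; beyond the scatter), which extends the separation from compound 1 to a third ring-amine head; none of the compounds shown goes against this. No measurement on hand bears on the origin of either step.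

The compounds shown leave open whether the piperazine ring or its 2-hydroxyethyl arm matters at this position, a question that an unsubstituted piperazin-1-yl head or a morpholine head could address. They also leave open whether a carboxylic acid in place of the terminal hydroxyl, or a longer chain carrying the same head, would keep the number in this range.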